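Cytotoxicity notes: from compound 2 to compound 3

The source may report more compounds than this note shows. Statements on the series, on what has been measured and on what is new or still open speak of the compounds shown alone.

Record so far in a toxicity assay on NIH3T3 cells (Mus musculus) for cytotoxicity, read by resazurin assay (a higher number here means that more compound is needed for the effect, a lower number that less compound is needed), for the series:
- compound 1 `COC(=O)c1ccc(NCc2cncn2Cc2ccccc2Cl)cc1-c1ccccc1` reads 10000 nM in this read-out
- compound 2 `COC(=O)c1ccc(NCc2cncn2Cc2ccc(OC)cc2)cc1-c1ccccc1` carries "not determined" (no result reported) as its entry

Compound 2 has no position on the numbers: its entry is "not determined" (no result reported) and gives no half-maximal effective concentration to compare with. Among the compounds with values here, the single number therefore belongs to compound 1, at 10000 nM in this assay so far.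

The next compound is compound 3 `COC(=O)c1ccc(NCc2cncn2Cc2cccc(Cl)c2)cc1-c1ccccc1`, still unmeasured. The structural change is 3-chlorophenyl in place of 4-methoxyphenyl on a saturated chain carbon bound to an aromatic nitrogen, which places 3-chlorophenyl in place of 4-methoxyphenyl on a saturated chain carbon bound to an aromatic nitrogen.

Within the data shown here, no measured step exists, and no step can be sized from compound 2 itself. Among the measured compounds shown here, the only guide is compound 1 at 10000 nM as a reference, so compound 3 is expected to fall near that level, with no shift beyond the usual scatter and no favoured direction. For compound 3 the estimated value is 10000 nM, with an expected range from 4000 nM to 25000 nM in this read-out.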

Compound 3, half-maximal effective concentration: > 10000 nM
Compound 3 ended at the assay's limit (the forecaster's own chance of this, stated with the estimate: 35%); the middle value lies on the limit itself.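

In this assay compound 3 gives > 10000 nM, which is a limit of the assay and not a number. Read as a step at this position, 3-chlorophenyl in place of 2-chlorophenyl on a saturated chain carbon bound to an aromatic nitrogen gives a number no lower from compound 1 to compound 3 (the limit leaves the size open), the first step in the series with a readable direction, and it shows that this change between two chlorophenyl groups does not bring the required concentration down. Only that direction can be taken from the step, and no size can be given because the result rests on the end of the read-out: the limit of > 10000 nM in this assay, at which 1 of the 3 values shown sits.

On these data alone, compound 2 carries no number, so the place of 4-methoxyphenyl relative to the two chlorophenyl groups stays open in this assay. Also open, as far as these compounds go, is how the read-out would respond at this position to a group of another kind, such as a phenyl ring bearing a carboxylic acid or an amine, or a longer chain in place of the benzyl group.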